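The compounds below may be only part of what the source reports. "The series", "measured", "known", "first", "only" and "open" are said of these compounds alone.

Of the compounds shown here, three sharing one core have been tested in a toxicity assay on THP-1 cells (Homo sapiens) for inhibition; a lower number here means that less compound is tolerated, a higher number that more compound is tolerated. They differ only in the group on the carbonyl carbon: pyridin-3-yl in compound 1 `COc1ccc(-c2cnc(NC(=O)c3cccnc3)n2C)cc1`, methyl in compound 2 `COc1ccc(-c2cnc(NC(C)=O)n2C)cc1` and 3-methoxyphenyl in compound 3 `COc1ccc(-c2cnc(NC(=O)c3cccc(OC)c3)n2C)cc1`. Compound 1 gives > 100000 nM as a limit of the assay, not a number. Compound 2 gives > 100000 nM, again only a limit. Compound 3, the starting point here, also stands only at a limit, > 100000 nM as its reading. The overall picture is the limit of > 100000 nM in this assay, at which 3 of the 3 values shown sit, for the whole set.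

Compound 4 `COc1ccc(-c2cnc(NC(=O)C3CCCCC3)n2C)cc1` differs from compound 3 in that same place, with cyclohexyl in place of 3-methoxyphenyl (cyclohexyl in place of 3-methoxyphenyl on a carbonyl carbon). Going by the values given here, the steps that bear on this swap the same group: a step that the two limits leave unreadable from compound 1 to compound 2, then a step that the two limits leave unreadable from compound 1 to compound 3, and finally a step that the two limits leave unreadable from compound 2 to compound 3 as well. None of them has a readable size, but no swap so far has produced a number. With a step that the two limits leave unreadable from compound 2 to compound 3 as a guide, no step beyond the scatter is expected in this assay, and neither direction is favoured. The expected size is a number no higher from compound 3 to compound 4 (the limit leaves the size open) on this estimate. For compound 4 the estimate is 100000 nM with an expected range from 40000 nM to 150000 nM and a limit is the most likely report.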

Compound 4, half-maximal cytotoxic concentration: > 100000 nM
Compound 4 was reported as a limit; the forecaster's own chance of this, stated with the estimate: 80%; the middle value lies on the limit itself.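

Compound 4 gives > 100000 nM in this assay as a limit of the assay, not a number. Its steps from compound 1, compound 2 and compound 3 therefore cannot be read. Whether any group on the carbonyl carbon can give a measured number in this assay stays open, as all the readings so far share one limit: the limit of > 100000 nM in this assay, at which 4 of the 4 values shown sit.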